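Benzothiazole series: methoxy on the fused ring

This account rests on a few compounds, and the source may have more. Where it says the series, first, only, none or still open, it means among the compounds named here.

Measured so far:
compound 1 `COc1cc(-c2ccc(C)n2-c2ccc(-c3nc4ccccc4s3)cc2)cc(OC)c1OC` — 4370 nM
compound 2 `COc1ccc2nc(-c3ccc(-n4c(C)ccc4-c4ccc(F)cc4)cc3)sc2c1` — 2800 nM

In a functional assay on MCF7 cells (Homo sapiens) for cytotoxicity, read by MTT assay, with a stated time of 72 h (on this read-out higher numbers stand for weaker inhibition and lower numbers for stronger inhibition), compound 1 gives 4370 nM, the highest of the two numbers in hand. Compound 2 gives 2800 nM in this assay, the nearest value, and the gap between the two lies within the scatter, so no order between them can be read. The two compounds differ in more than one place, so nothing about a single change follows from their values.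

Compound 3 `COc1ccc2nc(-c3ccc(-n4c(C)ccc4-c4cc(OC)c(OC)c(OC)c4)cc3)sc2c1` is not yet measured. It differs from compound 1 by methoxy in place of hydrogen on an aromatic carbon. For the measured compounds named here, no measured pair isolates this change. A step of a 1.2-fold lower number from compound 1 to compound 3 (0.10 log units; within the scatter) is expected, none beyond the scatter, in either direction. For compound 3 the estimated value in this assay is 3500 nM, with a range from 1500 nM to 8000 nM.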

Compound 3, half-maximal inhibitory concentration: 1520 nM
Estimate against measurement, compound 3: 2.3-fold (0.36 log units) above; the measured number falls inside the stated range.
By their numbers in this assay, from the lowest: compounds 3, 2 and 1 (each within the scatter of the next, the first and the last beyond it).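

In this assay, for the compounds shown here, the change from 1,3-benzothiazol-2-yl to 6-methoxy-1,3-benzothiazol-2-yl gives a 2.9-fold lower number from compound 1 to compound 3 (0.46 log units; beyond the scatter) and is the first single change that can be read. The step is modest but lies beyond the scatter, so this position on the fused ring accepts methoxy, and the number moves towards stronger inhibition. No measurement at hand accounts for the step.

Going by these compounds, the finding rests on one pair, so it remains open whether the same change would give a similar step with the fluorine-bearing aromatic ring of compound 2 in place of the corresponding ring of compound 1. Also open, on these data alone, is whether an amine, a hydroxyl or a longer ether such as ethoxy at this position would move the number in the same direction.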